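Bromo-to-hydrogen steps in a triazole-linked series: cytotoxicity notes

A few compounds are considered here, and "the series" means these few. Any claim that something is new, unique, unknown or untested is made for them only; others in the source may bear on it.

Measured in a functional assay on SMMC-7721 cells (Homo sapiens) for cytotoxicity, read by MTT assay, with a stated time of 4 days; a lower number here means a stronger inhibitor, a higher number a weaker inhibitor:
compound 1 `C=C1C[C@]23C[C@@]1(O)CC[C@@H]2c1cccc(C)c1[C@@H]3Cn1cc(-c2ccc(Br)cc2)nn1`: > 20000 nM
compound 2 `C=C1C[C@]23C[C@@]1(O)CC[C@H]2c1cc(Br)c(O)c(C)c1[C@@H]3Cn1cc(-c2ccc(F)cc2)nn1`: > 20000 nM
compound 3 `C=C1C[C@]23C[C@@]1(O)CC[C@@H]2c1cccc(C)c1[C@@H]3Cn1cc(-c2ccccc2)nn1`: > 20000 nM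

Each of these three values is a limit of this assay, not a number. For compound 1 the value > 20000 nM is such a limit. For compound 2 the value > 20000 nM is likewise a limit. For compound 3 the value > 20000 nM is a limit as well, so the limit of > 20000 nM in this assay, at which 3 of the 3 values shown sit, covers everything measured so far.

Among the compounds with values here, the one single-point step on record is a step that the two limits leave unreadable from compound 1 to compound 3, the change being (hydrogen in place of bromo on an aromatic carbon). How the core of compound 2 differs from that of compound 1 is not broken down here.

Compound 4 `C=C1C[C@]23C[C@@]1(O)CC[C@H]2c1ccc(O)c(C)c1[C@@H]3Cn1cc(-c2ccc(F)cc2)nn1` is not yet measured. It arises from compound 2 by hydrogen in place of bromo on an aromatic carbon, the same kind of change as that from compound 1 to compound 3, but at a different place: here the carbon sits ortho to a hydroxy group, meta to a fused ring, meta to a methyl group and para to a fused ring, whereas in the earlier pair it sits para to a large group.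

Given the limit of > 20000 nM in this assay, at which 3 of the 3 values shown sit, and the unreadable step that the two limits leave unreadable from compound 1 to compound 3, the step expected from compound 2 to compound 4 is a step that the limit leaves unreadable from compound 2 to compound 4 in this assay. Compound 4 is therefore estimated at 25000 nM, within 8000 nM to 80000 nM, most likely reported again as a limit.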

Compound 4, half-maximal inhibitory concentration: > 20000 nM
Compound 4 was reported as a limit; the forecaster's own chance of this, stated with the estimate: 80%; the middle value does not contradict the limit.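

Compound 2 and compound 4 are both reported only as limits in this assay, so no step can be read for this exchange of bromo for hydrogen: the limit of > 20000 nM in this assay, at which 4 of the 4 values shown sit.

The compounds shown leave open whether any member of the series reaches a readable half-maximal inhibitory concentration in this assay, and how large this exchange is at either place.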